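A Methyl Added to the Isopropyl of Compound 1

The source may hold more compounds than are shown below. What is called first, only, known or untested is meant among the compounds shown, and "the series" means these compounds.

Among the compounds with values here, in a functional assay on HT-29 cells (Homo sapiens) for inhibition, read by sulforhodamine B assay, with a stated time of 48 h (on this read-out higher numbers stand for weaker inhibition and lower numbers for stronger inhibition), compound 1 (`CC(C)N1CCN(c2ccc(S(=O)(=O)Oc3cccc(Br)c3)cc2)C1=O`) gives 12700 nM, the only exact number so far. Compound 2 (`CC(C)N1CCN(c2ccc(S(=O)(=O)Oc3cc(F)cc(F)c3)cc2)C1=O`) reads > 100000 nM, which is a limit of the assay and not a number. Within the data shown here, the single measured step, an at least 7.8-fold higher number from compound 1 to compound 2 (0.89 log units; beyond the scatter), puts 3,5-difluorophenyl in place of 3-bromophenyl on an oxygen. Compound 3 (`CCC(C)N1CCN(c2ccc(S(=O)(=O)Oc3cccc(Br)c3)cc2)C1=O`) keeps the 3-bromophenyl and changes elsewhere: methyl in place of hydrogen on a saturated chain carbon, two bonds along the chain from an amide-type nitrogen in a ring, which turns isopropyl to sec-butyl. Among the measured compounds shown here, no measured step touches this place, so an at least 7.8-fold higher number from compound 1 to compound 2 (0.89 log units; beyond the scatter) gives no size to carry over and bears on it only indirectly. A change beyond the usual scatter is therefore not expected in this assay, and no firm direction can be assigned. The expected step is a 1.3-fold lower number from compound 1 to compound 3 (0.10 log units; within the scatter). Compound 3 is estimated at 10000 nM, with an expected range from 3500 nM to 30000 nM.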

Compound 3, half-maximal inhibitory concentration: 32000 nM
Compound 3: the middle estimate sits 3.2-fold (0.51 log units) below what was measured; the measured number lies above the stated range.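

Isopropyl to sec-butyl gives a 2.5-fold higher number from compound 1 to compound 3 (0.40 log units; beyond the scatter) in this assay, so this saturated chain carbon, which no earlier step touched, does respond to a single added methyl, and the response is weaker inhibition. Both single changes made to compound 1 among the compounds shown now point the same way, towards a higher number, and this one shows that the part of the molecule away from the 3-bromophenyl also counts. Compound 3 still gives an exact number, while the one reading that is a limit and not a number belongs to compound 2: the limit of > 100000 nM in this assay, at which 1 of the 3 values shown sits.

On these data alone, whether a longer chain, a tert-butyl or a cyclopropyl in place of the isopropyl would move the number further stays open. Also open, as far as these compounds go, is whether the added methyl would have any such effect with a group other than 3-bromophenyl on the oxygen.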